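A few compounds are considered here, and "the series" means these few. Any claim that something is new, unique, unknown or untested is made for them only; others in the source may bear on it.

Measured compounds and their values in a physicochemical assay for solubility; on this read-out higher numbers stand for higher solubility and lower numbers for lower solubility:
Compound 1, `CNC(=O)c1cc(C(=O)N[C@H]2[C@@H]3COC[C@@H]32)cc2c1OC[C@H]2c1cccc(OC)c1`, gives >= 186 ug/mL, which is a limit of the assay and not a number.
Compound 2, `CNC(=O)c1cc(C(=O)NC2CC2)cc2c1OC[C@@]2(C)c1ccccc1`, gives >= 138 ug/mL, also a limit of the assay.
Compound 3, `CNC(=O)c1cc(C(=O)N[C@H]2C[C@@H]2C)cc2c1OC[C@@]2(C)c1ccccc1`, gives 3 ug/mL.

Compound 1 stands at the limit of >= 186 ug/mL in this assay, at which 1 of the 3 values shown sits, so for compound 1 only a limit is known, with no exact number behind it. Compound 4, `CNC(=O)c1cc(C(=O)N[C@H]2[C@@H]3COC[C@@H]32)cc2c1OC[C@H]2C1CCOCC1`, differs from compound 1 in one place: oxan-4-yl in place of 3-methoxyphenyl on a saturated ring carbon. Going by the values given here, the single measured step, an at least 46-fold lower number from compound 2 to compound 3 (1.66 log units; beyond the scatter), concerns a methyl in place of hydrogen on a saturated ring carbon, a different kind of change, and so it does not bear directly on the swap of a 3-methoxyphenyl for an oxan-4-yl. Among the compounds with values here, no measured pair shows this exchange, so the expectation rests on compound 1 alone. The step from compound 1 to compound 4 is estimated as a step that the limit leaves unreadable from compound 1 to compound 4, that is, no move beyond the scatter in this assay. Compound 4 is therefore expected to give about 200 ug/mL, with a range from 100 ug/mL to 400 ug/mL, and most likely again only a limit will be reported.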

Compound 4, solubility: >= 177 ug/mL
Compound 4: only a limit was reported (the forecaster's own chance of this, stated with the estimate: 70%); the middle value lies beyond the limit too.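

Compound 1 and compound 4 both return only a limit of the assay in this assay, so no step can be read between them. The compounds shown leave open how far their true numbers lie past those limits, and whether oxan-4-yl in place of 3-methoxyphenyl changes the read-out at all.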